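A few compounds are considered here, and "the series" means these few. Any claim that something is new, unique, unknown or untested is made for them only; others in the source may bear on it.

Compound 3 `O=C(CSc1nc(Nc2ccccc2)c2ccccc2n1)Nc1ccc(C(F)(F)F)cc1` gives the lowest number of the three in a functional assay on MGC-803 cells (Homo sapiens) for inhibition, read by MTT assay, with a stated time of 72 h (a higher number here means a weaker inhibitor, a lower number a stronger inhibitor), at 8670 nM. Compound 1 `COc1cccc(NC(=O)CSc2nc(Nc3ccccc3)c3ccccc3n2)c1` stands close by with 10000 nM, and the step of a 1.2-fold lower number from compound 1 to compound 3 (0.06 log units; within the scatter) stays within the scatter, so no order can be read between these two. Compound 2 `O=C(CSc1nc(Nc2ccccc2)c2ccccc2n1)Nc1ccc(Cl)cc1` gives 40400 nM, and the step of a 4.7-fold lower number from compound 2 to compound 3 (0.67 log units; beyond the scatter) lies beyond the scatter, as does a 4.0-fold higher number from compound 1 to compound 2 (0.61 log units; beyond the scatter).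

Compound 4 `O=C(CSc1nc(Nc2ccccc2)c2ccccc2n1)Nc1ccc(Cl)cc1Cl` differs from compound 3 in one place: 2,4-dichlorophenyl in place of 4-(trifluoromethyl)phenyl on an amide-type nitrogen. For the measured compounds named here, two measured steps bear on this change. The step of a 4.7-fold lower number from compound 2 to compound 3 (0.67 log units; beyond the scatter) shows that swapping chloro for trifluoromethyl on this phenyl lowered the number modestly; compound 4 runs that exchange backwards and adds a second chloro. The step of a 4.0-fold higher number from compound 1 to compound 2 (0.61 log units; beyond the scatter) shows that a chloro-bearing phenyl gave the highest number. Compound 4 is therefore expected to return toward the number of compound 2, a step of a 2.9-fold higher number from compound 3 to compound 4 (0.46 log units; beyond the scatter). For compound 4 the estimated value is 25000 nM, with a range from 8000 nM to 80000 nM.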

Compound 4, half-maximal inhibitory concentration: 12300 nM
Compound 4: the middle estimate sits 2.0-fold (0.31 log units) above what was measured, and the stated range covers the measured number.
By their numbers in this assay, from the lowest: compounds 3, 1 and 4 (each within the scatter of the next); then compound 2.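

Adding a second chloro to the phenyl on the amide-type nitrogen, which turns compound 2 into compound 4, moves the number down in this assay (a 3.3-fold lower number from compound 2 to compound 4 (0.52 log units; beyond the scatter)), so a chloro-bearing phenyl at this place does not by itself bring the high number of compound 2. The 2,4-dichlorophenyl group cannot be told apart from 4-(trifluoromethyl)phenyl (a 1.4-fold higher number from compound 3 to compound 4 (0.15 log units; within the scatter)) or from 3-methoxyphenyl (a 1.2-fold higher number from compound 1 to compound 4 (0.09 log units; within the scatter)), which leaves compound 2 alone apart from the other three. Nothing measured here accounts for the effect of the second chloro.

The compounds shown leave open whether this place tolerates anything other than a substituted phenyl, such as a longer alkyl chain on the amide-type nitrogen. They also leave open whether an amine or a carboxylic acid on the phenyl would take the number below that of compounds 1, 3 and 4.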